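The source may report more compounds than this note shows. Statements on the series, on what has been measured and on what is new or still open speak of the compounds shown alone.

Measured so far in a functional assay on cells for agonist activity at Free fatty acid receptor 1 (Rattus norvegicus), read by FLIPR and calcium flux; on this read-out higher numbers stand for an effect only at larger amounts of compound and lower numbers for an effect already at smaller amounts:
compound 1, `CC#C[C@@H](Cc1nnn[nH]1)c1ccc(OCc2ccc3scc(-c4cccnc4C)c3c2)cc1`, 20 nM
compound 2, `CC#C[C@@H](Cc1nnn[nH]1)c1ccc(OCc2ccc3scc(-c4cncnc4C)c3c2)cc1`, 18 nM

Compound 2 stands at the lower of the two numbers, yet the step of a 1.1-fold lower number from compound 1 to compound 2 (0.05 log units; within the scatter) keeps it within the scatter of compound 1. Compound 3, `CC#C[C@@H](Cc1nnn[nH]1)c1ccc(OCc2ccc3scc(-c4ccccc4C(F)(F)F)c3c2)cc1`, arises by 2-(trifluoromethyl)phenyl in place of 4-methylpyrimidin-5-yl on an aromatic carbon. Among the compounds with values here, the only measured step, a 1.1-fold lower number from compound 1 to compound 2 (0.05 log units; within the scatter), exchanged one six-membered heteroaryl for another and hardly moved this assay; the present change instead removes both ring hetero atoms and brings in a trifluoromethyl group, so it goes beyond what that step covers. Compound 3 is therefore estimated at 40 nM, between 12 nM and 130 nM, which means an expected step of a 2.2-fold higher number from compound 2 to compound 3 (0.35 log units; beyond the scatter).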

Compound 3, half-maximal effective concentration: 2 nM
Compound 3: middle estimate off by 20-fold (1.30 log units), on the high side; measured number outside the range, below it.
By their numbers in this assay, from the lowest: compound 3; then compounds 2 and 1 (each within the scatter of the next).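

In this assay the exchange for 2-(trifluoromethyl)phenyl gives a 9.0-fold lower number from compound 2 to compound 3 (0.95 log units; beyond the scatter) and a 10-fold lower number from compound 1 to compound 3 (1.00 log units; beyond the scatter) on this aromatic carbon, two ring bonds from the ring sulfur. The position therefore does discriminate between groups, which the two nitrogen-bearing rings of the earlier compounds had not shown. Nothing measured here explains the difference.

The change removes the ring hetero atoms and brings in trifluoromethyl at once, so the compounds shown do not separate these two parts. A plain phenyl ring, or a phenyl carrying methyl instead of trifluoromethyl, would address that.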